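Adding Chlorine to the Phenyl Ring of Compound 2

The compounds below may be only part of what the source reports. "The series", "measured", "known", "first", "only" and "open" are said of these compounds alone.

Two compounds share one core and differ only in the group attached to the carbonyl carbon. Compound 1 `CC(=O)/N=C1\NC2(CCCCO2)CCS1` carries a methyl there, and in a functional assay on the whole organism (strain CF-1) with Mus musculus as the target, in the writhing test, with a stated time of 15 min (on this read-out lower numbers stand for an effect already at smaller amounts and higher numbers for an effect only at larger amounts of compound), compound 1 gives 3.1 mg/kg. Compound 2 `O=C(/N=C1\NC2(CCCCO2)CCS1)c1ccccc1` carries a phenyl instead; in this assay compound 2 gives 5 mg/kg, the highest of the two numbers, though the step of a 1.6-fold higher number from compound 1 to compound 2 (0.21 log units; within the scatter) stays within the scatter. Compound 3 `O=C(/N=C1\NC2(CCCCO2)CCS1)c1ccc(Cl)cc1` is the next variation: chloro in place of hydrogen on an aromatic carbon, para to a large group on the six-membered aromatic ring of carbon only. For the measured compounds named here, no measured step touches this ring, and the one measured step, a 1.6-fold higher number from compound 1 to compound 2 (0.21 log units; within the scatter), lay within the scatter, so the numbers point in no direction. For compound 3 in this assay the expected step of no change at the digits printed from compound 2 to compound 3 (within the scatter) is therefore no larger than the scatter. The estimate for compound 3 is 5 mg/kg, with a range from 2.5 mg/kg to 10 mg/kg.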

Compound 3, dose for half-maximal effect: 1.1 mg/kg
Beside the measured number, compound 3's estimate is 4.5-fold (0.66 log units) above it; the measured number lies below the stated range.
By their numbers in this assay, from the lowest: compound 3; then compounds 1 and 2 (each within the scatter of the next).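

The ring of compound 2 had not been touched by any earlier step, and this position turns out to respond. In this assay, chloro in place of hydrogen on the aromatic carbon brings a 4.5-fold lower number from compound 2 to compound 3 (0.66 log units; beyond the scatter) and shows that a single added atom here can move the number past the scatter, though only modestly. The group on the carbonyl carbon also looks different now: phenyl in place of methyl gave a 1.6-fold higher number from compound 1 to compound 2 (0.21 log units; within the scatter) but 4-chlorophenyl in place of methyl gives a 2.8-fold lower number from compound 1 to compound 3 (0.45 log units; beyond the scatter) and so separates the two ends of this small set, while nothing available explains why the chloro compound needs a smaller dose.

The compounds shown leave open whether this shift belongs to chlorine alone or would also appear with fluoro, methoxy or an amine at this place. They also leave open what a longer chain would do in place of the methyl of compound 1.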